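The compounds below may be only part of what the source reports. "The series", "measured", "known", "first", "only" and "open" are said of these compounds alone.

In an ADME assay on microsomes from liver (Homo sapiens) for metabolic stability (a lower number here means slower removal, a higher number faster removal of the compound), compound 2 `Cc1ccc([C@H](C)NC(=O)Cn2nnc3ccccc3c2=O)cc1` gives < 9.9 mL/min/kg, which is a limit of the assay and not a number. Compound 1 `C[C@@H](NC(=O)Cn1nnc2ccccc2c1=O)c1ccc(Cl)cc1` gives < 9.9 mL/min/kg, also a limit. Compound 3 `Cc1ccc([C@@H](C)NC(=O)Cn2nnc3ccccc3c2=O)cc1` is still unmeasured. The change is the two compounds have the same atoms and bonds and differ only in configuration as drawn: 1 of 1 stereo elements differ; a stereocentre at a saturated chain carbon is drawn S in compound 2 and R in compound 3: the stereocentre at a saturated chain carbon is drawn S in compound 2 and R in compound 3. For the measured compounds named here, no measured pair shows what such a change does, so no shift beyond the scatter is expected in either direction. The expected step is a step that the limit leaves unreadable from compound 2 to compound 3. For compound 3 the estimate is 9.5 mL/min/kg, with an expected range from 7 mL/min/kg to 18 mL/min/kg.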

Compound 3, clearance: < 9.9 mL/min/kg
Compound 3 ended at the assay's limit; the forecaster's own chance of this, stated with the estimate: 70%; the middle value does not contradict the limit.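

Compound 1, compound 2 and compound 3 all end at a limit rather than a number, so no step among them can be read: the limit of < 9.9 mL/min/kg in this assay, at which 3 of the 3 values shown sit.

On these data alone, whether the configuration at the stereocentre, or methyl in place of chloro, changes the clearance in this assay stays open.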